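Coumarin amides: a sugar in place of acetyl

The source may report more compounds than this note shows. Statements on the series, on what has been measured and on what is new or still open speak of the compounds shown alone.

Measured compounds:
Compound 1, `COc1cccc(-c2cc(C(=O)Nc3cc4ccc(O[C@@H]5OC(C)(C)[C@H](OC)[C@@H](O)[C@H]5O)c(C)c4oc3=O)ccc2OC)c1`: 7500 nM
Compound 2, `COc1cccc(-c2cc(C(=O)Nc3cc4cc(OC)c(OC(C)=O)c(C)c4oc3=O)ccc2OC)c1`: 5720 nM

Of the compounds shown here, two have been measured in a functional assay on SK-BR-3 cells (Homo sapiens) for inhibition; on this read-out lower numbers stand for stronger inhibition and higher numbers for weaker inhibition. Compound 1 carries the oxanyl sugar and in this assay gives 7500 nM. Compound 2 carries an acetyl on the corresponding oxygen and in this assay gives 5720 nM, the lower of the two numbers, though the gap to compound 1 lies within the usual scatter of repeated measurements, so the two cannot be ordered.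

The step now considered leads from compound 2 to compound 3, `COc1cccc(-c2cc(C(=O)Nc3cc4cc(OC)c(O[C@@H]5OC(C)(C)[C@H](OC)[C@@H](O)[C@H]5O)c(C)c4oc3=O)ccc2OC)c1`. The change is 3,4-dihydroxy-5-methoxy-6,6-dimethyloxan-2-yl in place of acetyl on an oxygen on an aromatic ring. Compound 3 thus combines the methoxy of compound 2 with the sugar already present in compound 1. Since compound 1, which bears that same sugar, gives 7500 nM and compound 2 gives 5720 nM, no step beyond the scatter is expected in this assay; the estimated step is a 1.1-fold higher number from compound 2 to compound 3 (0.06 log units; within the scatter). Compound 3 is therefore expected to give about 6500 nM, within a range from 2500 nM to 17000 nM.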

Compound 3, half-maximal inhibitory concentration: 58800 nM
Beside the measured number, compound 3's estimate is 9.0-fold (0.96 log units) below it; the measured number lies above the stated range.
By their numbers in this assay, from the lowest: compounds 2 and 1 (each within the scatter of the next); then compound 3.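

In this assay, 3,4-dihydroxy-5-methoxy-6,6-dimethyloxan-2-yl in place of acetyl on an oxygen on an aromatic ring gives a 10-fold higher number from compound 2 to compound 3 (1.01 log units; beyond the scatter), so the group on this oxygen clearly matters when the methoxy is present. Going by these compounds alone, with the sugar held constant, methoxy in place of hydrogen on an aromatic carbon gives a 7.8-fold higher number from compound 1 to compound 3 (0.89 log units; beyond the scatter), which is the first reading of that change on its own. Neither step could be read from compounds 1 and 2 alone: they differ in two places, and their numbers lie within the scatter of each other, so that closeness said nothing about either change taken singly.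

Nothing among the data shown explains either step. The compounds shown leave open how a simple hydroxy or a chain ending in an amine on the same oxygen would read in this assay, and whether methoxy in place of hydrogen would give a similar step with acetyl, rather than the sugar, on that oxygen.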